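The source may report more compounds than this note shows. Statements on the series, on what has been measured and on what is new or still open speak of the compounds shown alone.

Compound 1, `CC(=O)N[C@@H]1CCN(c2cc(C)nn3c(-c4cccs4)c(C)nc23)C1`, in an ADME assay on microsomes from liver (Mus musculus) for metabolic stability, read by LC-MS, with NADPH named in the record, with a stated time of 60 min, tested at 1 uM, in the absence of a further agent (a lower number here means that less of the compound is left, a higher number that more of the compound is left), gives > 95%, which is a limit of the assay. Compound 2, `CC(=O)N[C@@H]1CCN(c2cc(C)nn3c(-c4ccc5cc[nH]c5c4)c(C)nc23)C1`, gives > 95%, again a limit. Compound 3, `COc1ccc(-c2c(C)nc3c(N4CC[C@@H](NC(=O)OCc5ccccc5)C4)cc(C)nn23)cc1OC`, gives > 95%, also a limit.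

Compound 3 thus sits at the limit of > 95% in this assay, at which 3 of the 3 values shown sit, and every value shown sits there with it. Among the measured compounds shown here, the one measured step, a step that the two limits leave unreadable from compound 1 to compound 2, is unreadable because both ends are limits.

Compound 4 is `COc1ccc(-c2c(C)nc3c(N4CC[C@@H](NS(N)(=O)=O)C4)cc(C)nn23)cc1OC`. Relative to compound 3 the change is sulfamoyl in place of benzyloxycarbonyl on an amine nitrogen. For the measured compounds named here, no measured step touches this kind of change, so nothing points to a loss of stability; the expectation is that compound 4 stays near the limit, with the step of a number at least 7 percentage points lower from compound 3 to compound 4 (that floor lies within the scatter) expected to lie within the scatter. Compound 4 is therefore estimated at 88%, between 65% and 95%.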

Compound 4, percent of the compound remaining: > 95%
Compound 4: only a limit was reported; the forecaster's own chance of this, stated with the estimate: 50%; middle value at least 7 percentage points from the limit.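

No step can be read from compound 3 to compound 4, since the results for both are limits, not numbers: the limit of > 95% in this assay, at which 4 of the 4 values shown sit.

Whether any of these compounds differ in this assay, and which change would lower the amount remaining, stays open.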